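Swapping Fluorine for a Methoxy Group on the Side Chain

A few compounds are considered here, and "the series" means these few. Any claim that something is new, unique, unknown or untested is made for them only; others in the source may bear on it.

Three compounds have so far been tested in a functional assay on HeLa cells (Homo sapiens) for cytotoxicity, read by WST assay, with a stated time of 48 h; on this read-out higher numbers stand for weaker inhibition and lower numbers for stronger inhibition:

Compound 1 `COc1cc(C(c2ccc(O)c(OC)c2)[C@@H](C)[C@H](C)CO)ccc1O`: > 100000 nM, which is a limit of the assay and not a number.
Compound 2 `COc1cc(C(c2ccc(O)c(OC)c2)[C@H](C)[C@H](C)CF)ccc1O`: 75000 nM.
Compound 3 `COc1cc(C(c2ccc(O)c(OC)c2)[C@H](C)[C@@H](C)CF)ccc1O`: 34000 nM.

Among the two compounds with a firm figure, compound 2 gives the higher number, and the step of a 2.2-fold lower number from compound 2 to compound 3 (0.34 log units; beyond the scatter) lies beyond the scatter. The two share all atoms and bonds and differ only in how one stereocentre is drawn (the fact that compounds 2 and 3 differ only in the configuration as drawn).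

The next compound, compound 4 `COC[C@@H](C)[C@H](C)C(c1ccc(O)c(OC)c1)c1ccc(O)c(OC)c1`, differs from compound 2 in one place: 2-(methoxymethyl)-1-methylpropyl in place of 2-(fluoromethyl)-1-methylpropyl on a saturated chain carbon bound to two aromatic carbons. The measured steps closest to this change are those in which the hydroxymethyl group gave way to fluoromethyl, an at least 1.3-fold lower number from compound 1 to compound 2 (0.12 log units; that floor lies within the scatter) and an at least 2.9-fold lower number from compound 1 to compound 3 (0.46 log units; beyond the scatter). For the measured compounds named here, both start from a limit, so their true size is not known; they show only that the fluoromethyl compounds reach numbers the hydroxymethyl compound did not. A methoxymethyl group is neither the hydroxymethyl nor the fluoromethyl seen so far, so the data give no firm direction. The step of a 1.1-fold higher number from compound 2 to compound 4 (0.03 log units; within the scatter) is therefore expected to stay within the scatter, possibly leaning toward a higher number. Compound 4 is estimated at 80000 nM, with a range from 40000 nM to 160000 nM.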

Compound 4, half-maximal inhibitory concentration: 58000 nM
Beside the measured number, compound 4's estimate is 1.4-fold (0.14 log units) above it; the range from low to high includes it.
By their numbers in this assay, from the lowest: compounds 3, 4 and 2 (each within the scatter of the next, the first and the last beyond it). At a limit, above all of these: compound 1.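

In this assay, the methoxymethyl group cannot be told apart from the fluoromethyl group on this side chain: a 1.3-fold lower number from compound 2 to compound 4 (0.11 log units; within the scatter) and a 1.7-fold higher number from compound 3 to compound 4 (0.23 log units; within the scatter) both stay inside the scatter. Compounds 2 and 3 lie beyond the scatter of each other, yet compound 4 lies within the scatter of both, so the saturated chain carbon bound to two aromatic carbons can carry 2-(methoxymethyl)-1-methylpropyl with no readable change from either fluoromethyl compound. The value of compound 1 is a limit of the assay and not a number, so putting methyl in place of hydrogen on that oxygen gives only a floor, an at least 1.7-fold lower number from compound 1 to compound 4 (0.23 log units; that floor lies within the scatter), and the true size of the step cannot be read: the limit of > 100000 nM in this assay, at which 1 of the 4 values shown sits.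

From the compounds shown here alone, whether an amine, a carboxylic acid or a longer chain at this place would move the number beyond the scatter remains open. Also open is whether a methoxymethyl compound with the other configuration at that stereocentre would shift the number as the fluoromethyl pair did in a 2.2-fold lower number from compound 2 to compound 3 (0.34 log units; beyond the scatter), the one comparison of configuration here: the fact that compounds 2 and 3 differ only in the configuration as drawn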